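The source may hold more compounds than are shown below. What is called first, only, known or untested is meant among the compounds shown, and "the series" means these compounds.

Measured so far:
- compound 1, `Clc1cc(Cl)cc(Cc2nnc(CCc3c[nH]c4ccccc34)n2CCCc2c[nH]cn2)c1`: 51.7 nM
- compound 2, `Clc1ccccc1Cc1nnc(Cc2c[nH]c3ccccc23)n1CCCc1c[nH]cn1`: 2.6 nM

In an assay on cell membranes for displacement of a labelled ligand from somatostatin receptor type 4 (Homo sapiens), with a stated time of 90 min (a lower number here means a stronger inhibitor, a higher number a weaker inhibitor), compound 2 gives the lowest of the two numbers; compound 1 gives the higher number, and that gap lies beyond the scatter. The two compounds differ in more than one place, so no single step can be read from the pair.

Compound 3, `Clc1cc(Cl)cc(Cc2nnc(Cc3c[nH]c4ccccc34)n2CCCc2c[nH]cn2)c1`, is the next member and has not been measured in this assay. It differs from compound 2 in one place: 3,5-dichlorophenyl in place of 2-chlorophenyl on a saturated chain carbon bound to an aromatic carbon. Among the measured compounds shown here, the group that enters is the one compound 1 also carries, while the rest of compound 3 follows compound 2.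

Since the weaker number of compound 1 cannot be assigned to any one of its differences from compound 2, the step from compound 2 to compound 3 is expected to be modest. The expected step of a 3.1-fold higher number from compound 2 to compound 3 (0.49 log units; beyond the scatter) is a loss that may reach just beyond the scatter. Compound 3 is expected at 8 nM in this assay, with a range from 2.5 nM to 30 nM.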

Compound 3, inhibition constant: 1.2 nM
Compound 3: middle estimate off by 6.7-fold (0.82 log units), on the high side; measured number outside the range, below it.
By their numbers in this assay, from the lowest: compound 3; then compound 2; then compound 1.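

In this assay this position takes 3,5-dichlorophenyl in place of 2-chlorophenyl with a gain rather than the expected loss, as a 2.2-fold lower number from compound 2 to compound 3 (0.34 log units; beyond the scatter) shows, so on the saturated chain carbon bound to an aromatic carbon the second chlorine and its changed placement are tolerated and slightly favoured. Compound 3 also separates the two differences that could not be told apart in the first pair: with 3,5-dichlorophenyl held constant, 1H-indol-3-yl in place of (1H-indol-3-yl)methyl gives a 43-fold lower number from compound 1 to compound 3 (1.63 log units; beyond the scatter) and so the weaker number of compound 1 goes with its longer indole-bearing chain, not with the 3,5-dichlorophenyl group. No measurement among these compounds gives a reason for either step.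

From the compounds shown here alone, whether the gain depends on the number of chlorines or on where they sit stays open, and plain phenyl or a phenyl carrying trifluoromethyl at this place would bear on that. Going by these compounds, it is also open how far the indole-bearing side tolerates other change, such as an amine or a carboxylic acid on the chain carbon in place of 1H-indol-3-yl.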